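Chloro to tert-Butyl Carried Across Two Related Cores

The source may report more compounds than this note shows. Statements on the series, on what has been measured and on what is new or still open speak of the compounds shown alone.

Compound 1 `C=C(Br)C(=O)Nc1ccc(/C=C2\SC(=O)N(Cc3ccc(Cl)cc3)C2=O)cc1` gives 2800 nM in a functional assay on CCRF-CEM cells (Homo sapiens) for cytotoxicity, read by cell counting, with a stated time of 3 days; on this read-out lower numbers stand for stronger inhibition and higher numbers for weaker inhibition. Compound 2 `C=C(Br)C(=O)Nc1ccc(/C=C2\SC(=O)N(Cc3ccc(C(C)(C)C)cc3)C2=O)cc1` differs from it by tert-butyl in place of chloro on an aromatic carbon, and in this assay compound 2 gives 830 nM, which is a 3.4-fold lower number from compound 1 to compound 2 (0.53 log units; beyond the scatter). Compound 3 `C=C(Br)C(=O)Nc1cccc(/C=C2\SC(=O)N(Cc3ccc(Cl)cc3)C2=O)c1` has the same atoms as compound 1 joined differently; the difference between the two cores is not broken down here. In this assay compound 3 gives 1400 nM. Compound 4 `C=C(Br)C(=O)Nc1cccc(/C=C2\SC(=O)N(Cc3ccc(C(C)(C)C)cc3)C2=O)c1` stands to compound 3 as compound 2 stands to compound 1, namely (tert-butyl in place of chloro on an aromatic carbon), the same change at the same place. Because the step of a 3.4-fold lower number from compound 1 to compound 2 (0.53 log units; beyond the scatter) lay beyond the scatter, a step of similar size is expected for compound 4, a 3.1-fold lower number from compound 3 to compound 4 (0.49 log units; beyond the scatter). Compound 4 is therefore estimated at 450 nM in this assay, with a likely range from 200 nM to 1200 nM.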

Compound 4, half-maximal inhibitory concentration: 3000 nM
Compound 4: middle estimate off by 6.7-fold (0.82 log units), on the low side, outside the stated range (above it).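

Set on the second core, tert-butyl in place of chloro on an aromatic carbon gives a 2.1-fold higher number from compound 3 to compound 4 (0.33 log units; beyond the scatter) in this assay. The change therefore does not carry from one core to the other, since the number falls on the first core and rises on the second, and the two steps differ: the same change on two cores in this assay, a 3.4-fold lower number (0.53 log units; beyond the scatter) from compound 1 to compound 2 and a 2.1-fold higher number (0.33 log units; beyond the scatter) from compound 3 to compound 4, 7.2-fold (0.86 log units) apart, beyond the scatter of two such steps This pair of steps does not show why the two cores part ways, nor does it show how any other change behaves on them.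

The compounds shown leave open whether a smaller group such as methyl, or a methoxy group, at the same place would follow the first core or the second. They also leave open how a third core would respond to this change.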